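Adding a Second Chlorine to Compound 1

This account rests on a few compounds, and the source may have more. Where it says the series, first, only, none or still open, it means among the compounds named here.

Measured so far:
compound 1: `ClCc1ccc(Cn2cnc3c(Cl)ncnc32)cc1` – 9450 nM
compound 2: `ClCc1cccc(Cn2cnc3c(Cl)ncnc32)c1` – 6310 nM
compound 3: `ClCc1ccc(Cn2cnc3nc(Cl)nc(Cl)c32)cc1` – 6020 nM

In a functional assay on UACC-62 cells (Homo sapiens) for cytotoxicity, read by sulforhodamine B assay, with a stated time of 48 h (on this read-out higher numbers stand for lower toxicity in this test and lower numbers for higher toxicity in this test), compound 1 gives 9450 nM, the highest of the three numbers shown, yet compound 2 and compound 3 both fall within the scatter of it, so the three cannot really be told apart. Compound 4, `ClCc1ccc(Cn2cnc3c(Cl)nc(Cl)nc32)cc1`, differs from compound 1 by chloro in place of hydrogen on an aromatic carbon. Within the data shown here, no measured pair shows the effect of this one change on its own; compound 3, which carries two chlorines at other places on the shared core, also sits within the scatter of compound 1. A small step is therefore expected in this assay, in no clear direction and not beyond the scatter. Compound 4 is estimated at 7500 nM, expected to lie between 2500 nM and 22000 nM. For compound 4 this expectation amounts to a 1.3-fold lower number from compound 1 to compound 4 (0.10 log units; within the scatter).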

Compound 4, concentration lethal to 50% of the cells: 9330 nM
Compound 4: the middle estimate sits 1.2-fold (0.09 log units) below what was measured; the measured number falls inside the stated range.
By their numbers in this assay, from the lowest: compounds 3, 2, 4 and 1 (each within the scatter of the next).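

In this assay, chloro in place of hydrogen on the aromatic carbon between two ring nitrogen atoms gives a 1.0-fold lower number from compound 1 to compound 4 (0.01 log units; within the scatter) as its step. Among these compounds, this is the first direct look at this one change, and in this single pair it leaves no change that can be told from the scatter. No available information explains this result.

Going by these compounds, whether an amine or a methoxy group on the same carbon would behave the same way remains open. So does whether this chloro step would look alike on the core of compound 2.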